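Phenyl for Thiophen-2-yl on the Amide Carbonyl: Cytotoxicity

The source may report more compounds than this note shows. Statements on the series, on what has been measured and on what is new or still open speak of the compounds shown alone.

Measured compounds:
compound 1, `O=C(/C=C/c1ccco1)c1ccc(NC(=O)c2cccs2)cc1`: 93000 nM
compound 2, `O=C(/C=C/c1ccco1)c1ccc(NC(=O)c2ccccc2)cc1`: > 100000 nM
compound 3, `O=C(/C=C/c1cccc([N+](=O)[O-])c1)c1ccc(NC(=O)c2cccs2)cc1`: 73000 nM

In a toxicity assay on FHC cells (Homo sapiens) for cytotoxicity, read by resazurin assay, with a stated time of 48 h (on this read-out lower numbers stand for higher toxicity in this test and higher numbers for lower toxicity in this test), compound 1 gives 93000 nM. Compound 3 gives 73000 nM in this assay. For compound 2 only a limit of this assay is known, > 100000 nM, not a number. Compound 1 and compound 3 differ in their cores by 3-nitrophenyl in place of furan-2-yl on a double-bonded chain carbon bound to a double-bonded chain carbon, and this step reads a 1.3-fold lower number from compound 1 to compound 3 (0.11 log units; within the scatter).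

The change studied here is phenyl in place of thiophen-2-yl on a carbonyl carbon. Its measured step is an at least 1.0-fold higher number from compound 1 to compound 2 (0.03 log units; that floor lies within the scatter), which rests on the limit of > 100000 nM in this assay, at which 1 of the 3 values shown sits, and so gives only a floor.

Compound 4, `O=C(/C=C/c1cccc([N+](=O)[O-])c1)c1ccc(NC(=O)c2ccccc2)cc1`, is not yet measured in this assay. It differs from compound 3 by phenyl in place of thiophen-2-yl on a carbonyl carbon; the place of the change is the same word for word as in the first pair, so it is the same change.

The expected step is a 1.2-fold higher number from compound 3 to compound 4 (0.09 log units; within the scatter), and this expectation rests on compound 1 and compound 2, whose step an at least 1.0-fold higher number from compound 1 to compound 2 (0.03 log units; that floor lies within the scatter) reached the limit (the limit of > 100000 nM in this assay, at which 1 of the 3 values shown sits). Compound 4 is therefore estimated at 90000 nM, expected to lie between 50000 nM and 160000 nM.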

Compound 4, half-maximal cytotoxic concentration: > 100000 nM
Compound 4: no number, only a limit; the forecaster's own chance of this, stated with the estimate: 40%; at least 1.1-fold (0.04 log units) between middle value and limit.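

In this assay compound 4 gives only a limit of the assay (> 100000 nM), so phenyl in place of thiophen-2-yl on a carbonyl carbon reads on this core only as a floor: an at least 1.3-fold higher number from compound 3 to compound 4 (0.13 log units; that floor lies within the scatter). Carrying the change from the core of compound 1 to the core of compound 3 thus meets no contradiction, but neither floor shows a step beyond the scatter, and the sizes of the step on the two cores cannot be compared: the same change on two cores in this assay, an at least 1.0-fold higher number (0.03 log units; that floor lies within the scatter) from compound 1 to compound 2 and an at least 1.3-fold higher number (0.13 log units; that floor lies within the scatter) from compound 3 to compound 4; the limit leaves it open whether they differ. The step from compound 2 to compound 4 cannot be read, and the limit caps all that the two phenyl compounds can show: the limit of > 100000 nM in this assay, at which 2 of the 4 values shown sit.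

As far as these compounds go, whether a pyridin-3-yl or a cyclohexyl group in place of phenyl on the carbonyl carbon would give a number inside the range of the test stays open. So does the reading of this change on a core that carries an amine or a carboxylic acid in place of 3-nitrophenyl or furan-2-yl.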